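Ring size change on the amide nitrogen of a sulfated sugar

The source may hold more compounds than are shown below. What is called first, only, known or untested is meant among the compounds shown, and "the series" means these compounds.

Compound 2 `CO[C@H]1O[C@H](CNC(=O)CN(C(C)=O)C2CCCCCC2)[C@@H](OS(=O)(=O)O)[C@H](OS(=O)(=O)O)[C@@H]1OS(=O)(=O)O` gives 410000 nM in an assay on isolated protein for binding affinity to fibroblast growth factor 2 (Homo sapiens), read by surface plasmon resonance (a lower number here means tighter binding, a higher number weaker binding), standing at the top of the two numbers measured, though the gap to compound 1 `CO[C@H]1O[C@H](CNC(=O)CN(CCOS(=O)(=O)O)C(C)=O)[C@@H](OS(=O)(=O)O)[C@H](OS(=O)(=O)O)[C@@H]1OS(=O)(=O)O`, at 240000 nM, lies within the scatter. That neighbouring step, a 1.7-fold higher number from compound 1 to compound 2 (0.23 log units; within the scatter), did not move this assay. Compound 3 `CO[C@H]1O[C@H](CNC(=O)CN(C(C)=O)C2CCCCC2)[C@@H](OS(=O)(=O)O)[C@H](OS(=O)(=O)O)[C@@H]1OS(=O)(=O)O` differs from compound 2 by cyclohexyl in place of cycloheptyl on an amide-type nitrogen. Within the data shown here, only that one step is on record, and it left the number unchanged; the present change is smaller still, so no step beyond the scatter is expected, a 1.0-fold lower number from compound 2 to compound 3 (0.01 log units; within the scatter). Compound 3 is therefore estimated at 400000 nM, between 180000 nM and 900000 nM.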

Compound 3, dissociation constant: 413000 nM
Compound 3: the middle estimate sits 1.0-fold (0.01 log units) below what was measured; low and high end bracket the measured number.
By their numbers in this assay, from the lowest: compounds 1, 2 and 3 (each within the scatter of the next).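

Cyclohexyl in place of cycloheptyl on the amide-type nitrogen gives a 1.0-fold higher number from compound 2 to compound 3 (0.00 log units; within the scatter) in this assay. Cyclohexyl in place of 2-(sulfooxy)ethyl gives a 1.7-fold higher number from compound 1 to compound 3 (0.24 log units; within the scatter), so a second ring size joins the earlier pair and all three groups now read alike within the scatter at this position. No available evidence bears on this result. Still open, going by these compounds, is whether a phenyl ring, or a chain ending in an amine or a carboxylic acid, on this nitrogen would give a step beyond the scatter.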